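This account rests on a few compounds, and the source may have more. Where it says the series, first, only, none or still open, it means among the compounds named here.

Working notes on the series.

Compound 1 `CC(C)Cc1ccc2c(NCCCNCc3ccco3)ccnc2c1` gives 16000 nM in an ADME assay on HepG2 cells (Homo sapiens) for cytotoxicity, read by luminescence, CellTiter-Glo and ATP content, with a stated time of 72 h; a higher number here means that more compound is needed for the effect, a lower number that less compound is needed. Compound 2 `c1ccc(Oc2ccc3c(NCCCNCc4ccco4)ccnc3c2)cc1` gives 15200 nM in this assay; the change phenoxy in place of isobutyl on an aromatic carbon gave a step of a 1.1-fold lower number from compound 1 to compound 2 (0.02 log units; within the scatter), so the two values cannot be ordered. Compound 3 `COc1ccc(F)cc1CNCCCNc1ccnc2cc(CC(C)C)ccc12` gives 2900 nM in this assay, the lowest of the three measured numbers, with both others beyond the scatter. Its core differs from that of compound 1 by 5-fluoro-2-methoxyphenyl in place of furan-2-yl on a saturated chain carbon bound to an amine nitrogen, a change that gave a 5.5-fold lower number from compound 1 to compound 3 (0.74 log units; beyond the scatter).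

Compound 4 `COc1ccc(F)cc1CNCCCNc1ccnc2cc(Oc3ccccc3)ccc12` has not yet been measured. It differs from compound 3 by phenoxy in place of isobutyl on an aromatic carbon, the same change already seen from compound 1 to compound 2, at the same place. An expected step of a 1.0-fold lower number from compound 3 to compound 4 (0.02 log units; within the scatter) rests on the earlier pair because a 1.1-fold lower number from compound 1 to compound 2 (0.02 log units; within the scatter) fell within the scatter. Compound 4 is therefore estimated at 2800 nM in this assay, between 1400 nM and 5600 nM.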

Compound 4, half-maximal effective concentration: 1500 nM
Estimate against measurement, compound 4: 1.9-fold (0.27 log units) above; the range from low to high includes it.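

In this assay, phenoxy in place of isobutyl on an aromatic carbon gave a 1.9-fold lower number from compound 3 to compound 4 (0.29 log units; within the scatter), and this step agrees with the one seen on the other core: the same change on two cores in this assay, a 1.1-fold lower number (0.02 log units; within the scatter) from compound 1 to compound 2 and a 1.9-fold lower number (0.29 log units; within the scatter) from compound 3 to compound 4, 1.8-fold (0.26 log units) apart, within the scatter of two such steps. 5-Fluoro-2-methoxyphenyl in place of furan-2-yl gave a 10-fold lower number from compound 2 to compound 4 (1.01 log units; beyond the scatter), and this change also carried from one core to the other: the same change on two cores in this assay, a 5.5-fold lower number (0.74 log units; beyond the scatter) from compound 1 to compound 3 and a 10-fold lower number (1.01 log units; beyond the scatter) from compound 2 to compound 4, 1.8-fold (0.26 log units) apart, within the scatter of two such steps. Both changes therefore carried across this one pair of cores, which does not show that either would carry to other cores in the series.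

Still open, as far as these compounds go, is whether these steps would hold with an amine or a carboxylic acid in place of phenoxy. From the compounds shown here alone, a longer chain joining the quinoline-side amine to the benzylic amine is equally open.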